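The source may report more compounds than this note shows. Statements on the series, on what has been measured and on what is new or still open speak of the compounds shown alone.

Measured so far:
Compound 1 `CCCCCCCCNC[C@@H]1OC[C@H](N)[C@@H]1O`: > 128000 nM
Compound 2 `CCCCCCCNC[C@@H]1OC[C@H](N)[C@@H]1O`: > 128000 nM

Both results come from a functional assay on B16-F10 cells (Mus musculus) for antiproliferative activity, read by MTT assay, with a stated time of 72 h; a lower number here means a stronger inhibitor, a higher number a weaker inhibitor. Compound 2 gives > 128000 nM, and this is a limit of the assay, not a number. Compound 1 gives > 128000 nM, which is also a limit. Among the compounds with values here, the one measured step between them is a step that the two limits leave unreadable from compound 1 to compound 2. Within the data shown here, the whole series so far stands at one result, (the limit of > 128000 nM in this assay, at which 2 of the 2 values shown sit), so no measured step offers a size to carry forward.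

The next compound is compound 3 `CCCCCCCNC[C@@H]1OC[C@H](N)[C@H]1O`. The change from compound 2 is purely one of shape as drawn: the two compounds have the same atoms and bonds and differ only in configuration as drawn: 1 of 3 stereo elements differ; a stereocentre at a saturated ring carbon is drawn S in compound 2 and R in compound 3. Among the measured compounds shown here, the measured step concerns chain length, not configuration, so it does not bear directly on this change, and no measured pair shows what such a switch does in this assay.

The expectation therefore rests on compound 2 alone, whose > 128000 nM is a limit. No clear move in either direction is expected, though a configuration change could still prove to matter. The expected step is a number no higher from compound 2 to compound 3 (the limit leaves the size open). Compound 3 is estimated at 128000 nM, with an expected range from 50000 nM to 256000 nM, and it will most likely be reported as a limit again.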

Compound 3, half-maximal inhibitory concentration: > 128000 nM
Compound 3 gave a limit, no number (the forecaster's own chance of this, stated with the estimate: 80%); the middle value sits exactly at the limit.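

Compound 3 gives only a limit in this assay, as compound 2 does, so no step can be read between these two compounds. The compounds shown leave open whether switching this one stereocentre changes antiproliferative activity at all, because every result so far sits at the same limit: the limit of > 128000 nM in this assay, at which 3 of the 3 values shown sit.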